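The source may hold more compounds than are shown below. What is called first, only, known or untested is meant among the compounds shown, and "the series" means these compounds.

Measured compounds in a functional assay on HCT-116 cells (Homo sapiens) for antiproliferative activity, read by MTT assay, with a stated time of 48 h; on this read-out lower numbers stand for stronger inhibition and higher numbers for weaker inhibition:
Compound 1 `Cc1ccccc1-n1nncc1CN1C(=O)C2(C(C#N)=C(N)Oc3c(N)cc4nc5ccccc5nc4c32)c2ccccc21` gives > 50000 nM, a limit of the assay.
Compound 2 `N#CC1=C(N)Oc2c(N)cc3nc4ccccc4nc3c2C12C(=O)N(Cc1cnnn1-c1ccc(F)cc1)c1ccccc12` gives > 50000 nM, also a limit.
Compound 3 `N#CC1=C(N)Oc2c(N)cc3nc4ccccc4nc3c2C12C(=O)N(Cc1cnnn1-c1ccccc1Cl)c1ccccc12` gives > 50000 nM, again a limit.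

Compound 3 therefore stands at the limit together with the other two compounds, as the limit of > 50000 nM in this assay, at which 3 of the 3 values shown sit, records. Compound 4 `N#CC1=C(N)Oc2c(N)cc3nc4ccccc4nc3c2C12C(=O)N(Cc1cnnn1-c1cccc(Br)c1)c1ccccc12` differs from compound 3 by 3-bromophenyl in place of 2-chlorophenyl on an aromatic nitrogen. The measured steps a step that the two limits leave unreadable from compound 1 to compound 2, a step that the two limits leave unreadable from compound 1 to compound 3 and a step that the two limits leave unreadable from compound 2 to compound 3 all alter this same aryl group on the triazole nitrogen, and none of them could be read, since every value sits at the limit. No step beyond the scatter can be predicted from them. Compound 4 is expected to give 60000 nM, with a range from 20000 nM to 200000 nM, most probably reported again only as a limit. The expected step that the limit leaves unreadable from compound 3 to compound 4 is accordingly estimated as none beyond the scatter.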

Compound 4, half-maximal inhibitory concentration: 26100 nM
Estimate against measurement, compound 4: 2.3-fold (0.36 log units) above; low and high end bracket the measured number.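

In this assay, among the compounds shown here, compound 4 gives 26100 nM as the first real number, so changing the aryl group on the triazole nitrogen can bring a compound inside the measurable range. The steps to it read an at least 1.9-fold lower number from compound 3 to compound 4 (0.28 log units; that floor lies within the scatter) and an at least 1.9-fold lower number from compound 2 to compound 4 (0.28 log units; that floor lies within the scatter) and an at least 1.9-fold lower number from compound 1 to compound 4 (0.28 log units; that floor lies within the scatter) as floors only, because compounds 1, 2 and 3 sit at a limit. Each floor lies within the scatter, so no real gain is established.

Compound 4 changes both the halogen and its ring place, and the compounds shown do not separate these two changes. Also open, on these data alone, is whether an amine or a carboxylic acid on this phenyl ring would give a lower number.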